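Urea series: chloro substitution on the terminal phenyl ring

The compounds below may be only part of what the source reports. "The series", "measured", "known", "first", "only" and "open" are said of these compounds alone.

Measured so far:
- compound 1 `CN(C)CCNc1nc(-c2ccc(NC(=O)Nc3ccc(Cl)cc3)cc2)nc2ccsc12`: 310 nM
- compound 2 `CN(C)CCNc1nc(-c2ccc(NC(=O)Nc3ccccc3Cl)cc2)nc2c(Cl)c(Cl)sc12`: 1350 nM
- compound 3 `CN(C)CCNc1nc(-c2ccc(NC(=O)Nc3ccc(Cl)cc3Cl)cc2)nc2ccsc12`: 2450 nM

All three were tested in a functional assay on MDA-MB-231 cells (Homo sapiens) for cytotoxicity, read by MTT assay, with a stated time of 72 h; on this read-out higher numbers stand for weaker inhibition and lower numbers for stronger inhibition. Among the compounds with values here, compound 1 and compound 3 share a core and differ by chloro in place of hydrogen on an aromatic carbon; that step, a 7.9-fold higher number from compound 1 to compound 3 (0.90 log units; beyond the scatter), is the only single-point comparison among the measured compounds. Compound 2 carries a different core; the difference between the two cores is not broken down here, and only the two values themselves can be set side by side.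

Compound 4 `CN(C)CCNc1nc(-c2ccc(NC(=O)Nc3ccc(Cl)cc3Cl)cc2)nc2c(Cl)c(Cl)sc12` is not yet measured. It differs from compound 2 by chloro in place of hydrogen on an aromatic carbon. Within the data shown here, this is the same kind of change as the one from compound 1 to compound 3, not the same: in the earlier step the entering chloro sits ortho to a large group, here it sits para to a large group, in both cases meta to a chloro group.

On the basis of a 7.9-fold higher number from compound 1 to compound 3 (0.90 log units; beyond the scatter), a move in the same direction is expected for compound 4, though with less confidence given the different surroundings. The expected step is a 2.6-fold higher number from compound 2 to compound 4 (0.41 log units; beyond the scatter). Compound 4 is therefore estimated at 3500 nM in this assay, in a range from 1200 nM to 10000 nM.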

Compound 4, half-maximal inhibitory concentration: 3500 nM
For compound 4 middle estimate and measured number coincide at the digits printed; the range from low to high includes it.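

In this assay, the change to 2,4-dichlorophenyl gives a 2.6-fold higher number from compound 2 to compound 4 (0.41 log units; beyond the scatter), with the entering chloro para to a large group and meta to a chloro group. The direction carries from one core to the other, but the size does not: the same change on two cores in this assay, a 7.9-fold higher number (0.90 log units; beyond the scatter) from compound 1 to compound 3 and a 2.6-fold higher number (0.41 log units; beyond the scatter) from compound 2 to compound 4, 3.0-fold (0.48 log units) apart, beyond the scatter of two such steps. These two pairs do not show whether the core or the place where the chloro enters sets that size, since the two differ together here, and two pairs give no rule for any further core.

Still open, on these data alone, is how the 2-chlorophenyl urea behaves on the core of compound 1 and how the 4-chlorophenyl urea behaves on the core of compound 2, the two pairings that would separate core from chloro position. Also open, as far as these compounds go, is whether the trend holds for a fluoro or methoxy group on the terminal phenyl ring, or with a morpholine in place of the dimethylamino group.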